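Chloro to Fluoro on the Aryl Ring: Antiproliferative Read-out

A few compounds are considered here, and "the series" means these few. Any claim that something is new, unique, unknown or untested is made for them only; others in the source may bear on it.

Compound 1 `COc1ccc(-c2cc(=O)c3c(OC)cc(OC)cc3n2S(=O)(=O)c2ccc(F)cc2)cc1`: > 65500 nM
Compound 2 `COc1ccc(-c2cc(=O)c3c(OC)cc(OC)cc3n2S(=O)(=O)c2ccc(Cl)cc2)cc1`: > 34400 nM
Compound 3 `COC(=O)c1cc(=O)c2cc(NC(=O)Nc3ccc(Cl)c(Cl)c3)ccc2[nH]1`: 5520 nM

In a functional assay on SUP-B15 cells (Homo sapiens) for antiproliferative activity, with a stated time of 72 h (on this read-out lower numbers stand for an effect already at smaller amounts and higher numbers for an effect only at larger amounts of compound), compound 1 gives only a limit, > 65500 nM. Compound 2 likewise gives only a limit in this assay, > 34400 nM. The change fluoro in place of chloro on an aromatic carbon therefore makes a step that is not readable, a step that the two limits leave unreadable from compound 2 to compound 1, because of the limit of > 34400 nM in this assay, at which 1 of the 3 values shown sits, and (the limit of > 65500 nM in this assay, at which 1 of the 3 values shown sits). Among the compounds with values here, compound 3 is the only one with a number in this assay, 5520 nM. How its core differs from that of compound 2 is not broken down here.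

Compound 4 `COC(=O)c1cc(=O)c2cc(NC(=O)Nc3ccc(F)c(Cl)c3)ccc2[nH]1` carries the same kind of change, (fluoro in place of chloro on an aromatic carbon); here the place is ortho to a chloro group, which it is not in compound 1. Within the data shown here, no measured step of this kind is readable, so compound 4 is expected near compound 3, with an estimated step of a 1.3-fold higher number from compound 3 to compound 4 (0.10 log units; within the scatter). Compound 4 is estimated at 7000 nM, between 2500 nM and 20000 nM.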

Compound 4, half-maximal effective concentration: > 12600 nM
Compound 4 ended at the assay's limit; the forecaster's own chance of this, stated with the estimate: 10%; middle value at least 1.8-fold (0.25 log units) from the limit.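

In this assay compound 4 gives > 12600 nM, which is a limit of the assay and not a number. On the core of compound 3, fluoro in place of chloro at a place ortho to a chloro group therefore makes an at least 2.2-fold higher number from compound 3 to compound 4 (0.35 log units; beyond the scatter). On the core of compound 2 the same change cannot be read, as compound 1 and compound 2 both give only limits, so this single step does not show whether the change carries from one core to the other.

The compounds shown leave open how far the true value of compound 4 lies from its limit. They also leave open how an amine or a nitrile would read at this place on the core of compound 3.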